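The compounds below may be only part of what the source reports. "The series", "measured", "known", "first", "only" and "open" are said of these compounds alone.

Compound 3, `CN1CCN(c2ccc(C3=NN(S(C)(=O)=O)C(c4ccc(N(C)C)cc4)C3)cc2)CC1`, gives -1.3% in a functional assay on NCI-H1975 cells (Homo sapiens) for inhibition, read by sulforhodamine B assay, tested at 10 uM; a lower number here means less inhibition, a higher number more inhibition at the concentration tested (going by the name of the read-out). Among the three measured compounds it stands second highest: compound 1, `COC(=O)CC(=O)N1N=C(c2ccc(N3CCN(C)CC3)cc2)CC1c1ccc(N(C)C)cc1`, gives -2.2%, within the scatter of compound 3, while compound 2, `CN1CCN(c2ccc(C3=NN(C(=O)c4ccc(C(F)(F)F)cc4)C(c4ccc(N(C)C)cc4)C3)cc2)CC1`, gives 93.2%, far above both. Compound 4 is `Cc1ccc(S(=O)(=O)N2N=C(c3ccc(N4CCN(C)CC4)cc3)CC2c2ccc(N(C)C)cc2)cc1`; its change from compound 3 is 4-methylphenyl in place of methyl on a sulfonyl sulfur. The measured steps that bear on this all concern the substituent on the amine nitrogen in the ring. a number 94.5 percentage points lower from compound 2 to compound 3 (beyond the scatter), so losing the (4-(trifluoromethyl)phenyl)carbonyl for methylsulfonyl removed nearly all inhibition. a number 95.4 percentage points higher from compound 1 to compound 2 (beyond the scatter), the only large rise in the set, came with 4-(trifluoromethyl)phenyl entering on the carbonyl carbon. a number 0.9 percentage points higher from compound 1 to compound 3 (within the scatter), so the swap of ((methoxycarbonyl)methyl)carbonyl for methylsulfonyl made no difference. Among the measured compounds shown here, no measured compound carries an aryl on a sulfonyl sulfur, so whether the carbonyl or the aryl of compound 2 carries its high inhibition cannot be told apart from these three numbers. An aryl entering on the sulfonyl sulfur is therefore expected to raise the read-out, probably by less than the step to compound 2 and with wide uncertainty, so a number 46.3 percentage points higher from compound 3 to compound 4 (beyond the scatter) is the expected step. Compound 4 is estimated at 45%, between 0% and 90%.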

Compound 4, a percentage reported as inhibition, at one concentration (the size of the read-out at that concentration, not a potency): 38.1%
Beside the measured number, compound 4's estimate is 6.9 percentage points above it, and the stated range covers the measured number.
By their numbers in this assay, from the lowest: compounds 1 and 3 (each within the scatter of the next); then compound 4; then compound 2.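

In this assay, an aryl on the sulfonyl sulfur gives real inhibition, with a number 39.4 percentage points higher from compound 3 to compound 4 (beyond the scatter) for 4-methylphenyl in place of methyl, and a number 40.3 percentage points higher from compound 1 to compound 4 (beyond the scatter) for (4-methylphenyl)sulfonyl in place of ((methoxycarbonyl)methyl)carbonyl, so among these four compounds the two with an aryl in this group stand above the two without, and none goes against that. A carbonyl on the ring nitrogen is therefore not required for inhibition, yet the two aryl-bearing groups are not equivalent: a number 55.1 percentage points lower from compound 2 to compound 4 (beyond the scatter) for (4-methylphenyl)sulfonyl in place of (4-(trifluoromethyl)phenyl)carbonyl, a swap that changes both the sulfonyl-or-carbonyl link and the substituent on the aryl, so the gap cannot be assigned to either one. No measurement at hand gives a reason for any of these steps.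

Still open, as far as these compounds go, is whether 4-(trifluoromethyl)phenyl on the sulfonyl sulfur would close that gap, which would separate the link from the aryl substituent. Also open, from the compounds shown here alone, is how an amine or a carboxylic acid on the aryl, or a longer chain on the sulfonyl sulfur, would read in this assay.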